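Capping the Sulfanyl Group of Compound 3 with Methyl

The source may report more compounds than this note shows. Statements on the series, on what has been measured and on what is new or still open speak of the compounds shown alone.

Of the compounds shown here, three have so far been measured in a functional assay on HT-29 cells (Homo sapiens) for cytotoxicity, read by MTT assay, with a stated time of 72 h; on this read-out higher numbers stand for weaker inhibition of growth and lower numbers for stronger inhibition of growth. Compound 1 `C[Se]c1nc(N)c2ccccc2n1` gives 27600 nM in this assay, compound 2 `CSc1ccc(CNc2nc(SC)nc3ncccc23)cc1` gives 4320 nM, and compound 3 `Sc1nc(NCc2ccccc2)c2ccccc2n1` gives 10100 nM. Compound 3 thus stands second highest of the three numbers: compound 2 is its nearest neighbour at a lower number, compound 1 its furthest at a higher number, and both gaps lie beyond the scatter.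

Compound 4 `CSc1nc(NCc2ccccc2)c2ccccc2n1` has not yet been measured. It differs from compound 3 by methyl in place of hydrogen on a sulfur: a methyl in place of hydrogen on a sulfur, so that the sulfanyl group of compound 3 becomes a methylsulfanyl group. For the measured compounds named here, no step between measured compounds shows how this change behaves. Compound 2 carries methylsulfanyl groups on a different core and gives the lowest number, while compound 1 carries a methylselanyl group and gives the highest, so the two offer no shared direction. A modest move toward a lower number is expected, not far beyond the scatter. For compound 4 the estimated value in this assay is 7000 nM, with a range from 2500 nM to 20000 nM. The step of a 1.4-fold lower number from compound 3 to compound 4 (0.16 log units; within the scatter) is expected to be small.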

Compound 4, concentration for 50% growth inhibition: 36500 nM
The estimate for compound 4 lay 5.2-fold (0.72 log units) below the measured number; the whole stated range lies below it.
By their numbers in this assay, from the lowest: compound 2; then compound 3; then compounds 1 and 4 (each within the scatter of the next).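

Placing methyl on this sulfur, whose other neighbour is an aromatic carbon, gives the first measured step at this position: in this assay the change goes toward weaker inhibition of growth, with a 3.6-fold higher number from compound 3 to compound 4 (0.56 log units; beyond the scatter). For the compounds shown here, no earlier pair of compounds differing in one place could show this, and the step now shows that, on this core, the methylsulfanyl group gives a higher number than the sulfanyl group. Nothing measured here accounts for this shift.

The compounds shown leave open whether a longer chain such as ethyl or a carboxylic acid such as a carboxymethyl group on the same sulfur would move the number further or bring it back toward that of compound 3. They also leave open whether the same change gives a step of this direction on any other core.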